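Dimethylamino in place of amino on compound 2

The compounds below may be only part of what the source reports. "The series", "measured", "known", "first", "only" and "open" are said of these compounds alone.

Measured so far:
- compound 1 `NC(=O)Cn1c(-c2ccc(Cl)cc2)nc2cccnc21`: 4.1 mg/kg
- compound 2 `NC(=O)Cn1c(-c2ccc(Br)cc2)nc2cccnc21`: 17.8 mg/kg
- compound 3 `Cc1ccc(-c2nc3cccnc3n2CC(N)=O)cc1`: 50.5 mg/kg

These values come from a functional assay on the whole organism with Mus musculus as the target; a lower number here means that less compound is needed, a higher number that more compound is needed for the effect. Compound 2 stands in the middle of the three, with compound 1 lower and compound 3 higher. Compound 4 `CN(C)C(=O)Cn1c(-c2ccc(Br)cc2)nc2cccnc21` keeps the core and the bromo group of compound 2 and changes its amide: dimethylamino in place of amino on a carbonyl carbon. Among the measured compounds shown here, no measured step touches this carbonyl carbon. The steps on the aromatic carbon, a 4.3-fold higher number from compound 1 to compound 2 (0.64 log units; beyond the scatter) and a 2.8-fold higher number from compound 2 to compound 3 (0.45 log units; beyond the scatter), bear on it only as a guide to size. A modest step to a higher number is therefore expected, although the data do not establish its direction. The estimated step is a 1.7-fold higher number from compound 2 to compound 4 (0.23 log units; within the scatter). Compound 4 is expected at 30 mg/kg, with an estimated range of 8 mg/kg to 110 mg/kg.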

Compound 4, dose for half-maximal effect: 7 mg/kg
The estimate for compound 4 lay 4.3-fold (0.63 log units) above the measured number; measured number below the stated range.
By their numbers in this assay, from the lowest: compounds 1 and 4 (each within the scatter of the next); then compound 2; then compound 3.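

The carbonyl carbon is a second place where a change moves the number: in this assay dimethylamino in place of amino gives a 2.5-fold lower number from compound 2 to compound 4 (0.41 log units; beyond the scatter) and so shows that, with bromo held constant, the effect does not depend on the amide hydrogens. The step runs in the opposite direction to the step from compound 2 to compound 3 on the aromatic carbon. Nothing available explains this shift.

Open, from the compounds shown here alone, is whether a methylamino, pyrrolidine or carboxylic acid at this carbonyl carbon would give a lower or a higher number. Also open, going by these compounds, is whether dimethylamino gives a like step with chloro on the aromatic carbon.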